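Removing the Chlorine from the Fused Ring of Compound 3

A few compounds are considered here, and "the series" means these few. Any claim that something is new, unique, unknown or untested is made for them only; others in the source may bear on it.

Three compounds sharing one core were tested in an ADME assay on RAW264.7 cells (Mus musculus) for cytotoxicity, read by MTT assay, with a stated time of 72 h, tested at 50 ug/mL; on this read-out higher numbers stand for more inhibition at the one concentration tested (going by the name of the read-out) and lower numbers for less inhibition. Compound 1 `COc1ccccc1N1CCN(C(=O)c2nc3cc(Cl)ccc3s2)CC1` gives 63.4% in this assay. Compound 2 `COc1ccc(N2CCN(C(=O)c3nc4cc(Cl)ccc4s3)CC2)cc1` gives 42.8% in this assay. Compound 3 `CC(=O)c1ccc(N2CCN(C(=O)c3nc4cc(Cl)ccc4s3)CC2)cc1` gives 30.8% in this assay, the lowest of the three numbers; the steps down to it are a number 12 percentage points lower from compound 2 to compound 3 (beyond the scatter) and a number 32.6 percentage points lower from compound 1 to compound 3 (beyond the scatter). The remaining measured step is a number 20.6 percentage points lower from compound 1 to compound 2 (beyond the scatter). All three steps alter the aryl group on the amine nitrogen in the ring, and none touches the chloro group on the fused ring.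

Compound 4 `CC(=O)c1ccc(N2CCN(C(=O)c3nc4ccccc4s3)CC2)cc1` is not yet measured. It differs from compound 3 in one place: hydrogen in place of chloro on an aromatic carbon. The chloro leaves an aromatic carbon of a six-membered aromatic ring of carbon only, part of a fused or bridged system of two rings, and a hydrogen atom enters. No measured step bears on this change, since every shown step alters a different part of the molecule. The numbers therefore give no basis for expecting a move beyond the scatter in either direction, and the expected step is a number 2.8 percentage points lower from compound 3 to compound 4 (within the scatter), close to no change. Compound 4 is expected to give about 28% in this assay, within a range from 10% to 46%, the width reflecting that nothing measured here shows how this position matters.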

Compound 4, a percentage reported as inhibition, at one concentration (the size of the read-out at that concentration, not a potency): 62.3%
Beside the measured number, compound 4's estimate is 34.3 percentage points below it; the whole stated range lies below it.
By their numbers in this assay, from the lowest: compound 3; then compound 2; then compounds 4 and 1 (each within the scatter of the next).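

In this assay the chloro on the aromatic carbon proves to be far from a silent spot: hydrogen in its place gives a number 31.5 percentage points higher from compound 3 to compound 4 (beyond the scatter) at the one concentration tested, which means more inhibition once the chlorine is gone. Among the compounds shown here, every earlier step changed the aryl group on the amine nitrogen in the ring, so this is the first reading of the position, and it shows that losing one heavy atom, with no ring, no hydrogen-bond donor or acceptor and no net charge involved, can move this number well beyond the scatter. No measurement shown here accounts for why this single atom matters so much.

Going by these compounds, the change has been read only with the 4-acetylphenyl group in place, so whether it acts in the same direction alongside the 2-methoxyphenyl group of compound 1 or the 4-methoxyphenyl group of compound 2 remains open. Also open, on these data alone, is how other groups on this aromatic carbon, such as a fluoro, a methyl or an amine, would read in this assay and whether any would stay close to the hydrogen or the chloro result.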